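The compounds below may be only part of what the source reports. "The series", "measured", "known", "first", "only" and "open" are said of these compounds alone.

The study concerns cytotoxicity toward a human liver-derived cell line, read in a functional assay on Huh7.5.1 cells (Homo sapiens) for cytotoxicity, read by MTT assay, with a stated time of 72 h; on this read-out lower numbers stand for higher toxicity in this test and higher numbers for lower toxicity in this test. Compound 1, `C=c1[nH]c(=O)/c(=C/c2ccc(C(=O)OC)cc2)[nH]c1=O`, gives in this assay > 20000 nM, which is a limit of the assay and not a measured number. Compound 2, `C=c1[nH]c(=O)/c(=C/c2cc(OC)c(OC)c(OC)c2)[nH]c1=O`, likewise returns > 20000 nM, again only a limit. Compound 3, `C=CC(C)(C)c1[nH]c2ccccc2c1/C=C1\NC(=O)C(C)(OC)NC1=O`, also stops at > 20000 nM, a limit as well. Compound 1 therefore stands where every shown value stands, namely at the limit of > 20000 nM in this assay, at which 3 of the 3 values shown sit. No pair of measured compounds differing in a single place is available, so nothing among these three shows how a change at the aromatic ring moves the reading in this assay.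

Compound 4, `C=c1[nH]c(=O)/c(=C/c2ccc(C(F)(F)F)cc2)[nH]c1=O`, differs from compound 1 by trifluoromethyl in place of methoxycarbonyl on an aromatic carbon. Since compound 1 sits at the limit with > 20000 nM, the step to compound 4 is expected to be none beyond the scatter, with a number no higher from compound 1 to compound 4 (the limit leaves the size open) as the estimated change. Compound 4 is expected to give 20000 nM in this assay, with a range from 10000 nM to 40000 nM, and most probably the assay will again report only a limit rather than a number for compound 4.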

Compound 4, half-maximal cytotoxic concentration: > 20000 nM
Compound 4 was reported as a limit; the forecaster's own chance of this, stated with the estimate: 85%; the middle value lies on the limit itself.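

In this assay compound 4 gives > 20000 nM, which is a limit and not a number. Compound 1 is also reported only as a limit, so the step from trifluoromethyl to methoxycarbonyl between these two compounds cannot be read. The compounds shown leave open how far any of them lies from that reading, as all stop at the same point: the limit of > 20000 nM in this assay, at which 4 of the 4 values shown sit.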